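A few compounds are considered here, and "the series" means these few. Any claim that something is new, unique, unknown or untested is made for them only; others in the source may bear on it.

Of the compounds shown here, two that share one core have numbers so far in a functional assay on Jurkat cells (Homo sapiens) for cytotoxicity, read by MTT assay, with a stated time of 24 h; a higher number here means that more compound is needed for the effect, a lower number that less compound is needed. Compound 1 `CCOC(=O)c1cc([Se]c2ccccc2)c2cc(Cl)ccc2n1`, which carries a chloro group, gives 53000 nM. Compound 2 `CCOC(=O)c1cc([Se]c2ccccc2)c2cc(C)ccc2n1`, which carries a methyl group in its place, gives 15300 nM, the lower of the two numbers, so less of compound 2 is needed for the effect. Compound 3 `CCOC(=O)c1cc([Se]c2ccccc2)c2ccccc2n1` has not been measured, and it differs from compound 2 in one place: hydrogen in place of methyl on an aromatic carbon. In words, this is hydrogen in place of methyl on an aromatic carbon.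

Among the compounds with values here, only one measured step bears on this change: a 3.5-fold lower number from compound 1 to compound 2 (0.54 log units; beyond the scatter), a modest step that came with methyl in place of chloro. It involves a different pair of groups, so it suggests a likely size but does not settle the outcome. Within the data shown here, with only this step from compound 2 as a guide, a rise in this assay no larger than that step is expected, and it may stay within the scatter. The estimated change is a 1.6-fold higher number from compound 2 to compound 3 (0.20 log units; within the scatter). For compound 3 the expected value is 24000 nM, with an estimated range of 10000 nM to 52000 nM.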

Compound 3, half-maximal effective concentration: 98200 nM
The estimate for compound 3 lay 4.1-fold (0.61 log units) below the measured number, and the stated range ends below it.
By their numbers in this assay, from the lowest: compound 2; then compounds 1 and 3 (each within the scatter of the next).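

In this assay the methyl group now stands out against a plain hydrogen on this aromatic carbon, with a 6.4-fold higher number from compound 2 to compound 3 (0.81 log units; beyond the scatter) for the loss of that single carbon, so the earlier gap between compound 1 and compound 2 can be read as a feature of the methyl group and not of the chloro group. The other new step, a 1.9-fold higher number from compound 1 to compound 3 (0.27 log units; within the scatter), shows that chloro and hydrogen cannot be told apart at this position, which leaves compound 2 alone on the low side of the set and makes this position sensitive to the choice of group, at least for these three. Nothing measured here explains why a methyl group should differ from both the others in this way.

As far as these compounds go, whether the lower number belongs to methyl alone stays open, since an ethyl group, a longer chain, a methoxy group or an amine at this place could side with compound 2 or with the other two. From the compounds shown here alone, all three compounds also keep the rest of the shared core the same, so it is unknown whether the methyl step would hold up if another part of the core were changed.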